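This account rests on a few compounds, and the source may have more. Where it says the series, first, only, none or still open, it means among the compounds named here.

Compound 1 `COc1cc(-n2ncnc2-c2ccccc2)cc(OC)c1OC` gives > 10000 nM as a limit
Compound 2 `COc1cc(-n2ncnc2-c2ccc(SC)cc2)cc(OC)c1OC` gives 50 nM as a number
Compound 3 `COc1cc(-n2ncnc2-c2ccc(F)cc2)cc(OC)c1OC` awaits measurement

Going by the values given here, in a functional assay on Jurkat cells (Homo sapiens) for antiproliferative activity, read by MTT assay, with a stated time of 72 h (a higher number here means a weaker inhibitor, a lower number a stronger inhibitor), compound 2 holds 50 nM as the only true number so far. Compound 1 gives > 10000 nM which is a limit of the assay. Among the compounds with values here, the single measured step is an at least 200-fold lower number from compound 1 to compound 2 (2.30 log units; beyond the scatter) and it came with methylsulfanyl in place of hydrogen on an aromatic carbon. Compound 3 differs by fluoro in place of methylsulfanyl on an aromatic carbon and so gives up that methylsulfanyl for fluoro. Going by the large step of an at least 200-fold lower number from compound 1 to compound 2 (2.30 log units; beyond the scatter) in this assay a sizeable move back to a higher number is expected, probably not the whole way. The expected change is a 30-fold higher number from compound 2 to compound 3 (1.48 log units; beyond the scatter) in this estimate. Compound 3 is estimated at 1500 nM with an expected range from 200 nM to 10000 nM in all.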

Compound 3, half-maximal inhibitory concentration: > 10000 nM
Compound 3: no number, only a limit; the forecaster's own chance of this, stated with the estimate: 25%; middle value at least 6.6-fold (0.82 log units) away from the limit.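

In this assay, fluoro in place of methylsulfanyl gives an at least 200-fold higher number from compound 2 to compound 3 (2.30 log units; beyond the scatter). So the gain seen at this place does not come with just any group on that aromatic carbon, and fluoro does not carry it. The step from compound 1 to compound 3 cannot be read, as both values are limits: the limit of > 10000 nM in this assay, at which 2 of the 3 values shown sit.

The compounds shown leave open whether the sulfur or the group's size matters here. As far as these compounds go, a dimethylamino or ethylsulfanyl group at this place would bear on that, and how far compound 3 lies past its limit also stays open.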